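Chloro in Place of Benzoyl on the Fused Core

The source may hold more compounds than are shown below. What is called first, only, known or untested is meant among the compounds shown, and "the series" means these compounds.

Measured compounds in a physicochemical assay for metabolic stability, read by HPLC, in phosphate buffer, at pH 7.4, tested at 10 uM; a lower number here means that the compound disappears faster, a higher number that the compound lasts longer:
compound 1, `O=C(NCCCCc1ccccc1)n1c(=O)oc2ccccc21`, 0.75 h
compound 2, `O=C(NCCCCc1ccccc1)n1c(=O)oc2cc(-c3ccc(F)cc3)ccc21`, whose result is a limit of the assay, > 5 h
compound 3, `O=C(c1ccccc1)c1ccc2c(c1)oc(=O)n2C(=O)NCCCCc1ccccc1`, 1.63 h

Among the two numbers given as numbers, compound 3 holds the highest half-life; compound 1 is its nearest neighbour, a 2.2-fold higher number from compound 1 to compound 3 (0.34 log units; beyond the scatter). The value of compound 2 is a limit only, and the evidence on it is the limit of > 5 h in this assay, at which 1 of the 3 values shown sits. The step from compound 2 to compound 3 is read against that limit: an at least 3.0-fold lower number from compound 2 to compound 3 (0.48 log units; beyond the scatter). From compound 1 to compound 2 the change is an at least 6.6-fold higher number from compound 1 to compound 2 (0.82 log units; beyond the scatter).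

Compound 4, `O=C(NCCCCc1ccccc1)n1c(=O)oc2cc(Cl)ccc21`, differs from compound 3 in one place: chloro in place of benzoyl on an aromatic carbon. The step from compound 1 to compound 3, where benzoyl entered, and the step from compound 2 to compound 3 both bear on this change, since compound 4 carries neither benzoyl nor 4-fluorophenyl on that aromatic carbon. Compound 4 is therefore expected to sit between compound 1 and compound 3. For compound 4 the expected step is a 1.6-fold lower number from compound 3 to compound 4 (0.21 log units; within the scatter), one that may not clear the scatter. The estimate for compound 4 in this assay is 1 h, ranging from 0.5 h to 2.5 h.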

Compound 4, half-life: 0.967 h
Compound 4: middle estimate off by 1.0-fold (0.01 log units), on the high side, and the stated range covers the measured number.
By their numbers in this assay, from the lowest: compounds 1, 4 and 3 (each within the scatter of the next, the first and the last beyond it). At a limit, above all of these: compound 2.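

In this assay, chloro on this aromatic carbon, meta to a fused ring and para to a fused ring, cannot be told apart from hydrogen: a 1.3-fold higher number from compound 1 to compound 4 (0.11 log units; within the scatter). Nor can it be told apart from benzoyl, a 1.7-fold lower number from compound 3 to compound 4 (0.23 log units; within the scatter), even though the printed step from hydrogen to benzoyl, a 2.2-fold higher number from compound 1 to compound 3 (0.34 log units; beyond the scatter), lies beyond the scatter, so chloro gives a result that falls in with both of the two groups that do differ from each other. Only 4-fluorophenyl stands clearly apart from chloro, read against a limit of the assay, an at least 5.1-fold lower number from compound 2 to compound 4 (0.71 log units; beyond the scatter), and compound 2 has a limit rather than a number: the limit of > 5 h in this assay, at which 1 of the 4 values shown sits.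

As far as these compounds go, how far compound 2 really lies beyond its limit remains open, and with it the true size of that step. Also open, from the compounds shown here alone, is whether a plain phenyl, an amine or a carboxylic acid on this aromatic carbon would fall in with chloro or with 4-fluorophenyl, and whether the separation seen here depends on an aromatic ring in the entering group.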